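The source may report more compounds than this note shows. Statements on the series, on what has been measured and on what is new or still open speak of the compounds shown alone.

In a functional assay on HCT-116 cells (Homo sapiens) for cytotoxicity, read by MTT assay, with a stated time of 48 h (a higher number here means a weaker inhibitor of growth, a lower number a stronger inhibitor of growth), compound 3, `C=CCn1c(C(F)(F)F)nc2cc(Cl)c(Cl)cc21`, gives 89200 nM, the top of the small range measured so far. Compound 2, `CC(C)n1c(C(F)(F)F)nc2cc(Cl)c(Cl)cc21`, gives 81900 nM, and the step between them, a 1.1-fold higher number from compound 2 to compound 3 (0.04 log units; within the scatter), places the two level with each other. Compound 1, `Clc1cc2nc(-c3ccccc3Cl)[nH]c2cc1Cl`, gives 23000 nM, a clearly lower number than compound 3 shows.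

Compound 4, `Nc1ccccc1Cn1c(C(F)(F)F)nc2cc(Cl)c(Cl)cc21`, carries 2-aminophenyl in place of vinyl on a saturated chain carbon bound to an aromatic nitrogen. For the measured compounds named here, only one measured step touches this substituent, a 1.1-fold higher number from compound 2 to compound 3 (0.04 log units; within the scatter), and it exchanges one small group for another, so it offers little guidance for a change of this size. Going by the values given here, its smallness shows only that this swap left the number unmoved. The other clue is weak: compound 1 also bears an additional aromatic ring and reaches 23000 nM, but it differs from compound 3 in more than one place and is no clean comparison. A modest move towards a lower number therefore seems more likely than none, with considerable uncertainty. The expected change is a 2.2-fold lower number from compound 3 to compound 4 (0.35 log units; beyond the scatter). For compound 4 the estimated value is 40000 nM, with an expected range from 12000 nM to 100000 nM.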

Compound 4, concentration for 50% growth inhibition: 26100 nM
For compound 4 the middle estimate is 1.5-fold (0.19 log units) above the measured one, and the stated range covers the measured number.
By their numbers in this assay, from the lowest: compounds 1 and 4 (each within the scatter of the next); then compounds 2 and 3 (each within the scatter of the next).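

In this assay the exchange of vinyl for 2-aminophenyl gives a 3.4-fold lower number from compound 3 to compound 4 (0.53 log units; beyond the scatter) and so moves the number beyond the scatter, whereas the earlier exchange on the aromatic nitrogen, a 1.1-fold higher number from compound 2 to compound 3 (0.04 log units; within the scatter), left it level. The substituent at this place can therefore shift growth inhibition, at least when a small group gives way to 2-aminophenyl, which brings a six-membered aromatic ring and a hydrogen-bond donor with it. The single step does not separate the contribution of the ring from that of its amine, and no measurement shown here explains the lower number.

A plain phenyl ring without the amine would show whether the ring alone accounts for the step, and a hydroxyl or a carboxylic acid in place of the amine would show whether the amine can be exchanged without losing it. Also open, on these data alone, is whether a longer chain carrying the 2-aminophenyl group would keep the lower number, and whether the step would hold on a core without the trifluoromethyl group.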